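Replacing the halogens on the benzyl group of compound 3

A few compounds are considered here, and "the series" means these few. Any claim that something is new, unique, unknown or untested is made for them only; others in the source may bear on it.

Measured in a functional assay on K562 cells (Homo sapiens) for antiproliferative activity, with a stated time of 72 h; a higher number here means a weaker inhibitor, a lower number a stronger inhibitor:
- compound 1 `OC[C@H]1O[C@@H](n2cnc3c(NCc4ccc(Br)cc4)ncnc32)[C@H](O)[C@@H]1O`: 68200 nM
- compound 2 `OC[C@H]1O[C@@H](n2cnc3c(NCc4ccc(F)cc4Cl)ncnc32)[C@H](O)[C@@H]1O`: 15600 nM
- compound 3 `OC[C@H]1O[C@@H](n2cnc3c(NCc4ccc(F)c(Cl)c4)ncnc32)[C@H](O)[C@@H]1O`: 5500 nM

Of these three, compound 3 gives the lowest number, which makes it the strongest inhibitor so far in this assay. The next structure, compound 4 `OC[C@H]1O[C@@H](n2cnc3c(NCc4cc(O)cc(O)c4)ncnc32)[C@H](O)[C@@H]1O`, keeps the shared core and alters only the aromatic group: 3,5-dihydroxyphenyl in place of 3-chloro-4-fluorophenyl on a saturated chain carbon bound to a nitrogen on an aromatic ring. In other words, 3,5-dihydroxyphenyl stands in place of 3-chloro-4-fluorophenyl on a saturated chain carbon bound to a nitrogen on an aromatic ring.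

All three measured steps were made at this same place. The largest is a 12-fold lower number from compound 1 to compound 3 (1.09 log units; beyond the scatter). The others are a 2.8-fold lower number from compound 2 to compound 3 (0.45 log units; beyond the scatter) and a 4.4-fold lower number from compound 1 to compound 2 (0.64 log units; beyond the scatter). Changes here have therefore mattered, by modest to large amounts. Within the data shown here, none of the measured compounds carries a dihydroxyphenyl group, so these steps give only a rough guide to size and direction. With compound 3 at the low end at 5500 nM, a modest to large rise in the number is expected, though this remains uncertain. The expected step is a 5.5-fold higher number from compound 3 to compound 4 (0.74 log units; beyond the scatter). The estimate for compound 4 is 30000 nM, with an expected range from 8000 nM to 100000 nM.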

Compound 4, half-maximal inhibitory concentration: > 166000 nM
Compound 4 ended at the assay's limit (the forecaster's own chance of this, stated with the estimate: 10%); at least 5.5-fold (0.74 log units) between middle value and limit.
By their numbers in this assay, from the lowest: compound 3; then compound 2; then compound 1. At a limit, above all of these: compound 4.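

In this assay compound 4 gives > 166000 nM, which is a limit of the assay and not a number: the limit of > 166000 nM in this assay, at which 1 of the 4 values shown sits.

The earlier steps shown here all moved among halogen-bearing benzyl groups and stayed within the measurable range, whereas 3,5-dihydroxyphenyl on the same saturated chain carbon takes activity out of that range, with an at least 30-fold higher number from compound 3 to compound 4 (1.47 log units; beyond the scatter). The other two comparisons point the same way, with an at least 10-fold higher number from compound 2 to compound 4 (1.02 log units; beyond the scatter) and an at least 2.4-fold higher number from compound 1 to compound 4 (0.38 log units; beyond the scatter), so compound 4 stands weaker than all three halogen-bearing compounds, including compound 1, the weakest of them. This change removes both halogens and brings in two hydroxyl groups, so the ring now has hydrogen-bond donors and acceptors where the 3-chloro-4-fluorophenyl group had none.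

The compounds shown cannot separate the loss of the halogens from the arrival of the hydroxyl groups, and an unsubstituted benzyl group or a benzyl group with a single hydroxyl would bear on that question. Going by these compounds, it also remains open whether methoxy groups in place of the two hydroxyl groups, or an amine or a carboxylic acid on the ring, would fare any better.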